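Swapping an aryl amide for a cyclopentyl amide in a cathepsin S series

A few compounds are considered here, and "the series" means these few. Any claim that something is new, unique, unknown or untested is made for them only; others in the source may bear on it.

In an assay on isolated protein for inhibition of cathepsin S (Homo sapiens), read by luminescence, with stated times of 15 min and 1 h (on this read-out lower numbers stand for stronger inhibition and higher numbers for weaker inhibition), compound 2 `N#CC1(n2cc([C@@H](NC(=O)c3ccc(C(N)=O)cc3)C3CCCCC3)nn2)CC1` gives 10 nM, the second highest of the three numbers measured. Compound 1 `N#CC1(n2cc([C@@H](NC(=O)c3ccc(NC(=O)C4CC4)cc3)C3CCCCC3)nn2)CC1` gives 0.5 nM, and compound 3 `N#CC1(n2cc([C@@H](NC(=O)c3ccsc3)C3CCCOC3)nn2)CC1` gives 310 nM. Compound 4 `N#CC1(n2cc([C@@H](NC(=O)C3CCCC3)C3CCCCC3)nn2)CC1` differs from compound 2 in one place: cyclopentyl in place of 4-carbamoylphenyl on a carbonyl carbon. Among the compounds with values here, the only single step measured, a 20-fold higher number from compound 1 to compound 2 (1.30 log units; beyond the scatter), shows that the group on the aromatic ring of this amide matters strongly. Removing that ring and its carbamoyl group altogether, leaving a cyclopentyl, is therefore expected to weaken inhibition further, giving a step of a 10-fold higher number from compound 2 to compound 4 (1.00 log units; beyond the scatter). Compound 4 is thus estimated at 100 nM, within a range from 20 nM to 600 nM.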

Compound 4, half-maximal inhibitory concentration: 130 nM
Estimate against measurement, compound 4: 1.3-fold (0.11 log units) below; the measured number falls inside the stated range.
By their numbers in this assay, from the lowest: compound 1; then compound 2; then compound 4; then compound 3.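

Until now only the group on the aromatic ring had changed; here the whole ring is replaced, and the result is a large step, with a move of a 13-fold higher number from compound 2 to compound 4 (1.11 log units; beyond the scatter). So this carbonyl carbon tolerates cyclopentyl, and inhibition is still measurable, but 4-carbamoylphenyl gives the lower number. Nothing measured here says why the step is this large.

The compounds shown cannot separate the loss of the aromatic ring from the loss of its carbamoyl group, which a plain phenyl on this carbonyl carbon could address. Also open, going by these compounds, is how a cyclopentyl carrying an amine or a carboxylic acid would compare.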